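The source may report more compounds than this note shows. Statements on the series, on what has been measured and on what is new or still open speak of the compounds shown alone.

Of the compounds shown here, three sharing one core have been measured in a functional assay on MDA-MB-231 cells (Homo sapiens) for inhibition, read by CellTiter-Glo, with a stated time of 72 h; a lower number here means that less compound is tolerated, a higher number that more compound is tolerated. Compound 1 `CC1=C(CC(=O)N2CCN(CCCN(C)C)CC2)c2cc(F)ccc2/C1=C\c1ccc([S+](C)[O-])cc1` gives 46200 nM. Compound 2 `CC1=C(CC(=O)N2CCN(c3ccncc3)CC2)c2cc(F)ccc2/C1=C\c1ccc([S+](C)[O-])cc1` gives 22700 nM, and compound 3 `CC1=C(CC(=O)N(C)CCN(C)S(C)(=O)=O)c2cc(F)ccc2/C1=C\c1ccc([S+](C)[O-])cc1` gives 12500 nM.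

Two changes connect them. Putting pyridin-4-yl in place of 3-(dimethylamino)propyl on the ring amine gives a 2.0-fold lower number from compound 1 to compound 2 (0.31 log units; beyond the scatter). Replacing the whole 4-(3-(dimethylamino)propyl)piperazin-1-yl on the carbonyl carbon with methyl(2-(methyl(methylsulfonyl)amino)ethyl)amino gives a 3.7-fold lower number from compound 1 to compound 3 (0.57 log units; beyond the scatter), while the corresponding change from the pyridin-4-yl piperazine gives a 1.8-fold lower number from compound 2 to compound 3 (0.26 log units; within the scatter). Compound 3 thus has the lowest number of the three, though its gap to compound 2 is within scatter and only its gap to compound 1 is beyond it.

Compound 4 `CC1=C(CC(=O)N(C)CCN(C)S(=O)(=O)c2cccc3ccccc23)c2cc(F)ccc2/C1=C\c1ccc([S+](C)[O-])cc1` is not yet measured. It differs from compound 3 only at the sulfonyl sulfur: naphthalen-1-yl in place of methyl on a sulfonyl sulfur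

Among the compounds with values here, no measured step touches the sulfonyl group itself, so none of the three steps bears directly on this change; all that is known is that the earlier changes at the amide end were modest. The step to compound 4 in this assay is therefore expected to be modest as well, estimated as a 1.6-fold lower number from compound 3 to compound 4 (0.19 log units; within the scatter), with the direction uncertain. Compound 4 is estimated at 8000 nM, within a range of 2500 nM to 30000 nM.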

Compound 4, half-maximal cytotoxic concentration: 29100 nM
Beside the measured number, compound 4's estimate is 3.6-fold (0.56 log units) below it; measured number inside the range.
By their numbers in this assay, from the lowest: compounds 3, 2, 4 and 1 (each within the scatter of the next, the first and the last beyond it).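

Within the data shown here, compound 4 gives the first reading at the sulfonyl sulfur, a position that none of the earlier steps touched. In this assay, naphthalen-1-yl in place of methyl gives a 2.3-fold higher number from compound 3 to compound 4 (0.37 log units; beyond the scatter), so this position does affect the read-out, and the change goes toward more compound being tolerated. The step is still only modest, even though a single carbon is replaced by two six-membered aromatic rings of carbon only, and no available evidence explains its direction or size.

With only methyl and naphthalen-1-yl at this sulfur, two points cannot show how the number changes across the groups that could sit there, such as an ethyl chain, a phenyl ring or naphthalen-2-yl. Going by these compounds, it also remains open whether naphthalen-1-yl would give a similar step on a compound with a different amide end, such as one carrying the 4-(pyridin-4-yl)piperazin-1-yl group of compound 2.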